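Swapping 2-Chlorophenyl for Isopropyl on the Shared Core

A few compounds are considered here, and "the series" means these few. Any claim that something is new, unique, unknown or untested is made for them only; others in the source may bear on it.

Of the compounds shown here, two have been tested in a functional assay on HL-60 cells (Homo sapiens) for cytotoxicity, read by MTT assay, with a stated time of 72 h; on this read-out higher numbers stand for weaker inhibition and lower numbers for stronger inhibition. Compound 1 `CCCCCc1nnc2nnc(N3CCCC3)nn12` gives 42500 nM in this assay. Going by the values given here, compound 2 `Clc1ccccc1-c1nnc2nnc(N3CCCC3)nn12` gives 2660 nM in this assay, the lowest of the two numbers, with compound 1 as its only neighbour. Among the compounds with values here, the single measured step is a 16-fold lower number from compound 1 to compound 2 (1.20 log units; beyond the scatter), recorded when 2-chlorophenyl took the place of pentyl. Compound 3 `CC(C)c1nnc2nnc(N3CCCC3)nn12` is the untested member; it differs from compound 2 in one place: isopropyl in place of 2-chlorophenyl on an aromatic carbon. The measured step bears directly on this change, since it moved between a group with no ring and the ring-bearing 2-chlorophenyl at the same carbon and was large. Because that step was a 16-fold lower number from compound 1 to compound 2 (1.20 log units; beyond the scatter) toward lower numbers, compound 3, which again carries a group with no ring, is expected to move the other way by an 11-fold higher number from compound 2 to compound 3 (1.05 log units; beyond the scatter), beyond the scatter. Compound 3 is therefore estimated at 30000 nM in this assay, within a range from 8000 nM to 100000 nM.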

Compound 3, half-maximal inhibitory concentration: 71200 nM
Beside the measured number, compound 3's estimate is 2.4-fold (0.38 log units) below it; the range from low to high includes it.
By their numbers in this assay, from the lowest: compound 2; then compounds 1 and 3 (each within the scatter of the next).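

In this assay, the result separates the 2-chlorophenyl group from both groups with no ring at this aromatic carbon: isopropyl in its place gives a 27-fold higher number from compound 2 to compound 3 (1.43 log units; beyond the scatter). The two groups with no ring cannot be told apart on this read-out, since isopropyl in place of pentyl gives a 1.7-fold higher number from compound 1 to compound 3 (0.22 log units; within the scatter), so among these three compounds, compound 2 alone stands apart, and a branched three-carbon group and a straight pentyl chain give no separable result. Nothing available gives a reason for this difference.

The compounds shown leave open whether the carbon ring or its chlorine accounts for the lower number of compound 2. They also leave open where a plain phenyl or a cyclohexyl group would stand at this carbon.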